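Swapping Cyclohexyl for Benzyl and the Inhibition Read-Out

A few compounds are considered here, and "the series" means these few. Any claim that something is new, unique, unknown or untested is made for them only; others in the source may bear on it.

Of the compounds shown here, three sharing one core have been tested in a functional assay on UO-31 cells (Homo sapiens) for inhibition, read by sulforhodamine B assay, with a stated time of 48 h, tested at 10 uM; on this read-out lower numbers stand for less inhibition and higher numbers for more inhibition at the one concentration tested (going by the name of the read-out). Compound 1 `COc1ccc(-c2cn3ccnc3c(-c3ccc4ncn(C5CCCCC5)c4c3)n2)cc1` gives 61.5% in this assay. Compound 2 `O=Cc1ccc(-c2cn3ccnc3c(-c3ccc4ncn(C5CCCCC5)c4c3)n2)cc1` gives 82.2%, the highest of the three. Compound 3 `FC(F)(F)c1cccc(-c2cn3ccnc3c(-c3ccc4ncn(C5CCCCC5)c4c3)n2)c1` gives 22.5%, the lowest. The measured steps between them all change the same end of the molecule, the 4-methoxyphenyl, 4-formylphenyl or 3-(trifluoromethyl)phenyl part: a number 20.7 percentage points higher from compound 1 to compound 2 (beyond the scatter), a number 39 percentage points lower from compound 1 to compound 3 (beyond the scatter), and a number 59.7 percentage points lower from compound 2 to compound 3 (beyond the scatter). Compound 2 therefore stands beyond the scatter above both of the others.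

Compound 4 `O=Cc1ccc(-c2cn3ccnc3c(-c3ccc4ncn(Cc5ccccc5)c4c3)n2)cc1` differs from compound 2 at a different place: benzyl in place of cyclohexyl on an aromatic nitrogen. None of the three measured steps touches this ring nitrogen or the group on it; all three vary the other end of the molecule. Going by the values given here, no measured step bears on this change, and the data give no ground to expect a shift in either direction beyond the scatter. As far as these compounds go, the expectation for compound 4 is best anchored at the value of compound 2, with a wide band for what is unknown. Put as a step, this expected change is a number 7.2 percentage points lower from compound 2 to compound 4 (within the scatter). Compound 4 is estimated to give 75% in this assay, within a range from 40% to 95%.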

Compound 4, a percentage reported as inhibition, at one concentration (the size of the read-out at that concentration, not a potency): 82.2%
Compound 4: the middle estimate sits 7.2 percentage points below what was measured, within the range that was stated.
By their numbers in this assay, from the lowest: compound 3; then compound 1; then compounds 2 and 4 (each within the scatter of the next).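

In this assay, going by these compounds alone, this is the first look at the group on the aromatic nitrogen, since the earlier compounds varied only the other end of the molecule, and benzyl in place of cyclohexyl gives no change at the digits printed from compound 2 to compound 4 (within the scatter). With the 4-formylphenyl end held fixed, this position therefore accepts both cyclohexyl, a non-aromatic ring with 6 heavy atoms, and benzyl, an aromatic ring with 7 heavy atoms counted with its linking carbon, with no visible difference at the one concentration tested. Nothing available here accounts for the two groups reading alike.

This single pair cannot show whether the same swap would read alike with the 4-methoxyphenyl or 3-(trifluoromethyl)phenyl end, or how the two compounds would compare across a range of concentrations. The compounds shown also leave open what happens on this nitrogen with groups of a different kind, such as a straight hexyl chain, or a chain ending in an amine or a carboxylic acid.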